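Isomeric oxadiazoles on the thioether of the aspartyl series

This account rests on a few compounds, and the source may have more. Where it says the series, first, only, none or still open, it means among the compounds named here.

Measured so far:
Compound 1 `CC(C)[C@H](NC(=O)COc1cccc2ccccc12)C(=O)N[C@@H](CC(=O)O)C(=O)CSc1nccn1C`: the value in a functional assay on Jurkat cells (Homo sapiens) for inhibition (on this read-out higher numbers stand for weaker inhibition and lower numbers for stronger inhibition), is the limit > 200000 nM.
Compound 2 `CC(C)[C@H](NC(=O)COc1cccc2ccccc12)C(=O)N[C@@H](CC(=O)O)C(=O)CSc1nc(-c2ccccc2)no1`: in this assay compound 2 gives 102000 nM.

Among the compounds with values here, compound 2 holds the only number in this assay; the other value is a limit, not a number. Within the data shown here, the one step measured, an at least 1.9-fold lower number from compound 1 to compound 2 (0.29 log units; that floor lies within the scatter), rests on that limit, as the limit of > 200000 nM in this assay, at which 1 of the 2 values shown sits, shows, and its floor lies within the scatter.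

Compound 3 `CC(C)[C@H](NC(=O)COc1cccc2ccccc12)C(=O)N[C@@H](CC(=O)O)C(=O)CSc1nnc(-c2ccccc2)o1` carries 5-phenyl-1,3,4-oxadiazol-2-yl in place of 3-phenyl-1,2,4-oxadiazol-5-yl on a sulfur. Among the measured compounds shown here, the single measured step swaps the whole heteroaryl group and carries no information on how the two oxadiazole isomers compare; the change in compound 3 keeps the same atoms and rearranges them. No step beyond the scatter is therefore expected in this assay, in either direction. For compound 3 the expected value is 100000 nM, within 40000 nM to 250000 nM. The step this estimate means is a 1.0-fold lower number from compound 2 to compound 3 (0.01 log units; within the scatter).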

Compound 3, half-maximal inhibitory concentration: 150000 nM
Compound 3: the middle estimate sits 1.5-fold (0.18 log units) below what was measured; low and high end bracket the measured number.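

Moving from 3-phenyl-1,2,4-oxadiazol-5-yl to 5-phenyl-1,3,4-oxadiazol-2-yl on the sulfur keeps the same atoms and gives, in this assay, a 1.5-fold higher number from compound 2 to compound 3 (0.17 log units; within the scatter), so this read-out does not tell the two oxadiazole isomers apart. Against the 1-methyl-1H-imidazol-2-yl group, the second isomer gives an at least 1.3-fold lower number from compound 1 to compound 3 (0.12 log units; that floor lies within the scatter), so neither oxadiazole has a step from that group beyond the scatter. Compound 1 has a limit, not a number: the limit of > 200000 nM in this assay, at which 1 of the 3 values shown sits.

Still open, going by these compounds, is whether any group on this sulfur can bring the number clearly under those of compound 2 and compound 3. Also open, on these data alone, is whether the phenyl on the oxadiazole matters at all, which a methyl or a pyridyl in its place would test.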